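Benzyl thioamide and thioimidates: half-life in buffer

The source may hold more compounds than are shown below. What is called first, only, known or untested is meant among the compounds shown, and "the series" means these compounds.

Measured so far in a physicochemical assay for pharmacokinetics, in phosphate buffer, with a stated time of 30 min, at pH 7.4, tested at 1 mM, in the presence of a further agent that is not named here; a higher number here means that the compound lasts longer, a lower number that the compound disappears faster:

compound 1, `S=C(NCc1ccccc1)c1cccs1`, gives 0.126 h
compound 2, `COc1ccc(C(=N)SCc2ccccc2)cc1`, gives 0.0955 h
compound 3, `N=C(SCc1ccccc1)c1cccs1`, gives 0.111 h

All three numbers sit close together. Compound 2 has the lowest of the three, but compound 3 is nearest to it and compound 1 furthest, and both gaps fall within the scatter of this assay, so no order among the three can be read from these values. Within the data shown here, no pair of the measured compounds differs in a single place, so no measured step is available to guide the next change.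

Compound 4, `N=C(SCc1ccccc1)c1ccc(O)cc1`, is not yet measured. It differs from compound 2 by hydrogen in place of methyl on an oxygen on an aromatic ring. The stated difference is a single heavy atom at the oxygen and touches neither the thioimidate nor the benzyl group; nothing in the three measured values gives a reason to expect an effect beyond the scatter. The step expected is a 1.0-fold higher number from compound 2 to compound 4 (0.02 log units; within the scatter), in neither direction beyond the scatter. Compound 4 is therefore estimated at 0.1 h, with a range from 0.05 h to 0.2 h.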

Compound 4, half-life: 0.085 h
Beside the measured number, compound 4's estimate is 1.2-fold (0.07 log units) above it; the range from low to high includes it.
By their numbers in this assay, from the lowest: compounds 4, 2, 3 and 1 (each within the scatter of the next).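

Compound 4 gives the series its first measured step between compounds that differ in one place: methoxy to hydroxy on the aromatic ring, with a 1.1-fold lower number from compound 2 to compound 4 (0.05 log units; within the scatter) in this assay. In this place, removing the methyl from the oxygen therefore leaves the half-life within the scatter, and a free hydroxy is tolerated as well as a methoxy without a readable change. No available measurement bears on why this step is so small.

Still open, from the compounds shown here alone, is whether another group in this place, such as an amine, a carboxylic acid or a longer chain on the oxygen like butoxy, would move the half-life beyond the scatter. Also open, going by these compounds, is whether methoxy to hydroxy would give a similar step on a different core, such as the core of compound 3.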